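Two Methoxy Groups on the Amide Aryl Ring

The source may hold more compounds than are shown below. What is called first, only, known or untested is meant among the compounds shown, and "the series" means these compounds.

Three compounds share one core and differ only in the aryl group attached to the amide carbonyl. Compound 1 `COc1ccc(C(=O)Nc2cccc(-c3oc4cc(-c5ccc(F)cc5)ccc4c(=O)c3O)c2)cc1` gives 4820 nM in a functional assay on HeLa cells (Homo sapiens) for antiproliferative activity, read by CCK-8 assay, with a stated time of 72 h; on this read-out higher numbers stand for weaker inhibition and lower numbers for stronger inhibition. Compound 2 `Cc1ccc(C(=O)Nc2cccc(-c3oc4cc(-c5ccc(F)cc5)ccc4c(=O)c3O)c2)cc1` gives 6190 nM in this assay, the second highest of the three numbers, and compound 3 `O=C(Nc1cccc(-c2oc3cc(-c4ccc(F)cc4)ccc3c(=O)c2O)c1)c1ccc(Br)cc1` gives 9740 nM in this assay. The steps among them are small: a 1.3-fold higher number from compound 1 to compound 2 (0.11 log units; within the scatter), a 1.6-fold higher number from compound 2 to compound 3 (0.20 log units; within the scatter), and only a 2.0-fold higher number from compound 1 to compound 3 (0.31 log units; beyond the scatter).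

Compound 4 `COc1cc(OC)cc(C(=O)Nc2cccc(-c3oc4cc(-c5ccc(F)cc5)ccc4c(=O)c3O)c2)c1` carries the change (3,5-dimethoxyphenyl in place of 4-methylphenyl on a carbonyl carbon). Among the measured compounds shown here, the only measured step that bears on it is the one from compound 1 to compound 2, in which a methoxy and a methyl are exchanged on an aromatic carbon, a 1.3-fold higher number from compound 1 to compound 2 (0.11 log units; within the scatter), which stays within the scatter. The change here introduces two methoxy groups in a different arrangement, so that single step is a loose guide at best. Compound 4 is therefore expected to show a 1.2-fold lower number from compound 2 to compound 4 (0.09 log units; within the scatter) in this assay, either nothing beyond the scatter or at most a slight shift toward a lower number. Compound 4 is estimated at 5000 nM, with a range from 2000 nM to 12000 nM.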

Compound 4, half-maximal inhibitory concentration: 2700 nM
Beside the measured number, compound 4's estimate is 1.9-fold (0.27 log units) above it; low and high end bracket the measured number.
By their numbers in this assay, from the lowest: compounds 4, 1, 2 and 3 (each within the scatter of the next, the first and the last beyond it).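

In this assay, replacing a single para-free... 

Correction, final text:

In this assay, among the compounds shown here, the 3,5-dimethoxyphenyl group gives a step on this carbonyl carbon that clears the scatter against two neighbours, with a 2.3-fold lower number from compound 2 to compound 4 (0.36 log units; beyond the scatter) and a 3.6-fold lower number from compound 3 to compound 4 (0.56 log units; beyond the scatter), whereas the earlier compounds offered only one such step, and a marginal one. The gain over 4-methoxyphenyl is not established, however, with a 1.8-fold lower number from compound 1 to compound 4 (0.25 log units; within the scatter), so the second methoxy group and its different placement cannot be credited with any separate effect, and compound 1 itself stays within the scatter of compound 2. Nothing available here gives a reason for these differences.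

Going by these compounds, it remains open whether a single methoxy group on the 3-position of the phenyl ring would read like compound 1 or like compound 4. On these data alone, how a 3,4,5-trimethoxyphenyl group, a dimethylamino group or a carboxylic acid would behave on this aryl ring also remains open.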